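The source may hold more compounds than are shown below. What is called first, only, known or untested is meant among the compounds shown, and "the series" means these compounds.

Measured compounds:
compound 1 `CC1CCC(=NNc2ccccc2)c2ncc(C(=O)O)c(=O)n21`: 1.2 umol/kg
compound 2 `C[C@H]1CCC(=NNc2ccccc2)c2ncc(C(=O)O)c(=O)n21`: 1 umol/kg; > 100 umol/kg (2 entries)
compound 3 `CC1CC/C(=N\Nc2cccc(Cl)c2)c2ncc(C(=O)O)c(=O)n21`: see below

These three compounds share one core and differ at the group attached to the amine nitrogen. In a functional assay on the whole organism for inhibition, with Rattus norvegicus as the target (a lower number here means that less compound is needed, a higher number that more compound is needed for the effect), compound 1 gives 1.2 umol/kg. For the measured compounds named here, compound 2, which is drawn with a defined configuration where compound 1 is not, shows a scattered picture: the several entries of compound 2 in this assay, 1 umol/kg; > 100 umol/kg (2 entries), so two of its entries are limits and only one is a number. Compound 3 stands at a limit in this assay, > 100 umol/kg, and a further entry for it also gives no single number. Among the three values shown, one sits at that limit (the limit of > 100 umol/kg in this assay, at which 1 of the 3 values shown sits), so compound 3 is the compound for which no number at all is known.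

The next compound, compound 4 `Cc1ccccc1N/N=C1\CCC(C)n2c1ncc(C(=O)O)c2=O`, has not yet been measured in this assay. Its difference from compound 3 is 2-methylphenyl in place of 3-chlorophenyl on an amine nitrogen. Going by the values given here, no step between two measured compounds is known for this change, so there is no measured pattern to lean on. Compound 3 itself offers only a limit. With the phenyl-bearing compounds 1 and 2 near the low end and compound 3 at a limit, compound 4 is expected to fall somewhere between, with the step of an at least 10-fold lower number from compound 3 to compound 4 (1.00 log units; beyond the scatter) estimated to move toward a measurable number. The estimate for compound 4 is 10 umol/kg, within a range from 1 umol/kg to 100 umol/kg, with a real chance that only a limit is reported again.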

Compound 4, dose for 50% inhibition: > 100 umol/kg
Compound 4 ended at the assay's limit (the forecaster's own chance of this, stated with the estimate: 45%); middle value at least 10-fold (1.00 log units) from the limit.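

The values of compound 3 and compound 4 cannot be compared, and no step between them can be read, because both are limits and not numbers: the limit of > 100 umol/kg in this assay, at which 2 of the 4 values shown sit.

The compounds shown leave open whether 2-methylphenyl or 3-chlorophenyl on the amine nitrogen needs less compound for the effect in this assay.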